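A few compounds are considered here, and "the series" means these few. Any claim that something is new, unique, unknown or untested is made for them only; others in the source may bear on it.

Measured so far in an assay for inhibition of Pro-cathepsin H (Homo sapiens), read by fluorescence, tested at 50 uM; a higher number here means more inhibition at the concentration tested (going by the name of the read-out), a lower number less inhibition:

- compound 1, `Cc1ccc(-c2nc(S)[nH]c(=O)n2)cc1`: 6.58%
- compound 2, `O=c1nc(SCc2ccccc2)nc(SCc2ccc([N+](=O)[O-])cc2)[nH]1`: "not determined" (no result reported)

Compound 1 gives 6.58% in this assay, a small read-out at the test concentration. Among the compounds with values here, compound 2 is reported as "not determined" (no result reported) in this assay, so the series holds one value only and no step between measured compounds. Compound 2 therefore cannot be placed on the scale at all; the only anchor for the series is the low read-out of compound 1, and nothing shows whether compound 2 sits near it.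

Compound 3, `N#Cc1ccc(CSc2nc(SCc3ccccc3)nc(=O)[nH]2)cc1`, is the next compound to go into this assay. It is reached from compound 2 by one change: cyano in place of nitro on an aromatic carbon. Within the data shown here, with no value for compound 2 and no measured step anywhere in the set, no size or direction can be read off for this change; the working expectation is a shift not beyond the scatter, that is, nothing that would clearly separate compound 3 from compound 2 once both are measured.

For compound 3 the estimate in this assay is 8%, with a range from 0% to 25%, resting only on the low read-out that compound 1 shows in this assay.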

Compound 3, a percentage reported as inhibition, at one concentration (the size of the read-out at that concentration, not a potency): 1.55%
Compound 3: middle estimate off by 6.5 percentage points, on the high side; measured number inside the range.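

In this assay, within the data shown here, compound 3 gives 1.55% while compound 2 stands as "not determined" (no result reported) so no step between the two can be read. The compounds shown leave open what cyano in place of nitro does to the read-out. No evidence at hand bears on this result.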